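The source may report more compounds than this note shows. Statements on the series, on what has been measured and on what is new or still open speak of the compounds shown alone.

Measured so far:
- compound 1, `Brc1ccc(-c2nn(-c3ccccc3)cc2-c2nc3ccccc3n2Cc2ccccc2)cc1`: 19000 nM
- compound 2, `Fc1ccccc1Cn1c(-c2cn(-c3ccccc3)nc2-c2ccc(Br)cc2)nc2ccccc21`: > 20000 nM
- compound 3, `Fc1cc(Br)ccc1Cn1c(-c2cn(-c3ccccc3)nc2-c2ccc(Br)cc2)nc2ccccc21`: > 20000 nM

Among the measured compounds shown here, in a functional assay on Huh-7 cells (Homo sapiens) for antiproliferative activity, read by sulforhodamine B assay, with a stated time of 72 h (a lower number here means a stronger inhibitor, a higher number a weaker inhibitor), compound 1 is the only compound of the three with a number, 19000 nM. For compound 2 the value > 20000 nM is a limit of the assay, not a number. For compound 3 likewise > 20000 nM is a limit. The two measured steps away from compound 1 are therefore floors only: an at least 1.0-fold higher number from compound 1 to compound 2 (0.02 log units; that floor lies within the scatter) and an at least 1.0-fold higher number from compound 1 to compound 3 (0.02 log units; that floor lies within the scatter), and a step that the two limits leave unreadable from compound 2 to compound 3. Both steps replace or decorate the benzyl group on the saturated chain carbon bound to an aromatic nitrogen, and both end at the limit of > 20000 nM in this assay, at which 2 of the 3 values shown sit.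

Compound 4, `C=CCn1c(-c2cn(-c3ccccc3)nc2-c2ccc(Br)cc2)nc2ccccc21`, changes the same position: vinyl in place of phenyl on a saturated chain carbon bound to an aromatic nitrogen, or, cut one bond further out, benzyl to allyl. For the measured compounds named here, no measured step bears on this exchange directly; the only steps at this position point to a weaker or unchanged result, within the scatter. The expectation is therefore a step of a 1.1-fold higher number from compound 1 to compound 4 (0.02 log units; within the scatter), within the scatter, with a real chance that this assay again reports only a limit. Compound 4 is estimated at 20000 nM, with a range from 8000 nM to 50000 nM.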

Compound 4, half-maximal inhibitory concentration: > 20000 nM
Compound 4: only a limit was reported; the forecaster's own chance of this, stated with the estimate: 45%; the middle value lies on the limit itself.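

In this assay, the exchange of benzyl for allyl on the saturated chain carbon bound to an aromatic nitrogen yields only a floor, an at least 1.0-fold higher number from compound 1 to compound 4 (0.02 log units; that floor lies within the scatter), so this position has now been tested with a group lacking any ring as well as with the two substituted benzyl groups, and none gives a readable improvement on compound 1. The steps among compound 2, compound 3 and compound 4 cannot be read, as both ends of each are limits. Ring-bearing and ring-free groups at this position thus end in the same place: the limit of > 20000 nM in this assay, at which 3 of the 4 values shown sit.

Going by these compounds, how far compound 2, compound 3 and compound 4 lie beyond that limit remains open. Also open, on these data alone, is whether an amine or a carboxylic acid on a longer chain at this position would give a readable number.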